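Cytotoxicity notes on a urea series: compound 1 to compound 4

This account rests on a few compounds, and the source may have more. Where it says the series, first, only, none or still open, it means among the compounds named here.

Compound 1 `COc1ccc(NC(=O)Nc2cc(C)nc3ccccc23)cc1` — an ADME assay on HepG2 cells (Homo sapiens) for cytotoxicity, with a stated time of 72 h; on this read-out lower numbers stand for an effect already at smaller amounts and higher numbers for an effect only at larger amounts of compound: > 25000 nM, a limit of the assay.
Compound 2 `COc1ccc(NC(=O)Nc2cc(C)nc3ccccc23)cc1F` — this assay: > 25000 nM, a limit of the assay.
Compound 3 `Cc1cc(NC(=O)Nc2cccc(C(F)(F)F)c2)c2ccccc2n1` — this assay: 21000 nM.

Compound 1 stands only at a limit in this assay, with no number of its own. Compound 2 sits at the same limit, which is the limit of > 25000 nM in this assay, at which 2 of the 3 values shown sit. Among the compounds with values here, compound 3 alone gives a number, and no step is computed between it and compound 1. Within the data shown here, the single computed step, a step that the two limits leave unreadable from compound 1 to compound 2, is left unreadable by the two limits and therefore gives no size.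

Compound 4 `Cc1cc(NC(=O)Nc2ccc(N(C)C)cc2)c2ccccc2n1` differs from compound 1 in one place: dimethylamino in place of methoxy on an aromatic carbon. Among the measured compounds shown here, no measured step covers an exchange of the methoxy itself, and the one step that touches the same ring carries no readable size. The expectation for compound 4 is therefore a value at or around the same limit, so that the step that the limit leaves unreadable from compound 1 to compound 4 is expected to stay within the usual scatter. In this assay compound 4 is estimated at 30000 nM, with a range from 15000 nM to 60000 nM.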

Compound 4, half-maximal effective concentration: > 25000 nM
Compound 4: only a limit was reported; the forecaster's own chance of this, stated with the estimate: 70%; the middle value is on the limit's open side.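

No step can be read from compound 1 to compound 4, as both stand only at a limit in this assay: the limit of > 25000 nM in this assay, at which 3 of the 4 values shown sit.

The compounds shown leave open whether dimethylamino in place of methoxy shifts the half-maximal effective concentration at all, and by how much.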